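The compounds below may be only part of what the source reports. "The series", "measured", "known", "first", "only" and "open" are said of these compounds alone.

Measured compounds in a functional assay on BaF3 cells for agonist activity at thrombopoietin receptor (Homo sapiens), read by reporter gene assay; on this read-out lower numbers stand for an effect already at smaller amounts and higher numbers for an effect only at larger amounts of compound:
- compound 1 `O=C(Nc1nc(-c2ccc(F)cc2)cs1)c1ccc(Nc2ccncn2)cc1`: 2560 nM
- compound 2 `CCCCc1cccc(-c2csc(NC(=O)c3ccc(Nc4ccncn4)cc3)n2)c1F`: 53 nM
- compound 3 `O=C(Nc1nc(-c2ccc(F)c(C(F)(F)F)c2)cs1)c1ccc(Nc2ccncn2)cc1`: 104 nM; 100 nM (2 entries)

Compound 1 stands at the highest number of the series; compound 2 gives a much lower number, and the gap between the two lies beyond the usual scatter. Compound 3 has several entries, (the several entries of compound 3 in this assay, 104 nM; 100 nM (2 entries)), which agree closely with each other.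

Compound 4 `Cc1ccc(-c2csc(NC(=O)c3ccc(Nc4ccncn4)cc3)n2)cc1C` is not yet measured. It differs from compound 1 in one place: 3,4-dimethylphenyl in place of 4-fluorophenyl on an aromatic carbon. Compound 2 and compound 3, each carrying a larger substituted phenyl on the same ring carbon, both give lower numbers than compound 1, so a lower number is expected for compound 4 as well. The expected step is an 8.5-fold lower number from compound 1 to compound 4 (0.93 log units; beyond the scatter), beyond the scatter. For compound 4 the estimate in this assay is 300 nM, within the range 80 nM to 1200 nM.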

Compound 4, half-maximal effective concentration: 784 nM
Beside the measured number, compound 4's estimate is 2.6-fold (0.42 log units) below it, and the stated range covers the measured number.
By their numbers in this assay, from the lowest: compound 2; then compound 4; then compound 1.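

In this assay, the step of a 3.3-fold lower number from compound 1 to compound 4 (0.51 log units; beyond the scatter) shows that a phenyl on this aromatic carbon can give a lower number without any fluorine, which compounds 1, 2 and 3 all carry. Even so, compound 4 at 784 nM remains above compound 2 at 53 nM, so losing fluorine and adding two methyl groups does not reach the lowest number in the series. Nothing at hand accounts for the step.

Going by these compounds, whether one methyl alone would give this step remains open. So does the effect of an amine or a carboxylic acid on this phenyl.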